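From Benzylamino to 6-Fluoro-1,2,3,4-tetrahydroisoquinolin-2-yl: Expected Half-Life

This account rests on a few compounds, and the source may have more. Where it says the series, first, only, none or still open, it means among the compounds named here.

Compound 1 `C=CC(=O)N1CC(NC(=O)Cn2c(C3CC3)c(C(=O)N3CCc4c(cccc4OC)C3)c3cc(Br)ccc32)C1`: 1.67 h
Compound 2 `C=CC(=O)N1CC(NC(=O)Cn2cc(C(=O)NCc3ccccc3)c3cc(Br)ccc32)C1`: 1.67 h
Compound 3 `C=CC(=O)N1CC(NC(=O)Cn2c(C)c(C(=O)N3CCc4c(cccc4OC)C3)c3cc(Br)ccc32)C1`: 1.67 h

Of the compounds shown here, three have been measured in a physicochemical assay for pharmacokinetics, read by LC-MS, in phosphate buffer, at pH 7.4, in the presence of a further agent that is not named here (on this read-out higher numbers stand for a longer-lived compound and lower numbers for a shorter-lived compound), and all three stand at the same value. For the measured compounds named here, compound 2 is level with compound 1 and with compound 3, and the one single-point step, no change at the digits printed from compound 1 to compound 3 (within the scatter), is within the scatter. Compound 4 `C=CC(=O)N1CC(NC(=O)Cn2cc(C(=O)N3CCc4cc(F)ccc4C3)c3cc(Br)ccc32)C1` differs from compound 2 by 6-fluoro-1,2,3,4-tetrahydroisoquinolin-2-yl in place of benzylamino on a carbonyl carbon. Going by the values given here, no measured step covers this change. Compound 1 and compound 3 carry a tetrahydroisoquinoline amide and compound 2 a benzylamide, yet they give the same half-life, so no shift beyond the scatter is expected from the amide change. The estimated step is no change at the digits printed from compound 2 to compound 4 (within the scatter). Compound 4 is therefore expected to give 1.67 h, between 1 h and 2.8 h.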

Compound 4, half-life: 1.67 h
Compound 4: middle estimate and measured number agree at the digits printed; the range from low to high includes it.
By their numbers in this assay, from the lowest: compounds 1, 2, 3 and 4 (each within the scatter of the next).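

Setting 6-fluoro-1,2,3,4-tetrahydroisoquinolin-2-yl in place of benzylamino on a carbonyl carbon gives no change at the digits printed from compound 2 to compound 4 (within the scatter) in this assay, the only measured step at this position. The larger group, which also removes the amide hydrogen and brings in a fluorine, leaves the reading level. Nothing shown explains this result. The compounds shown leave open whether a morpholin-4-yl or a piperidin-1-yl group on this carbonyl carbon would read the same, and whether any group here can move the half-life at all.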